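A few compounds are considered here, and "the series" means these few. Any claim that something is new, unique, unknown or untested is made for them only; others in the source may bear on it.

Working notes on the series. All compounds share the core of compound 1 `Nc1cccc(/C=C2\SC(=O)N(Cc3ccc(F)cc3)C2=O)c1` and are read in a functional assay on FM3A cells (Mus musculus) for cytotoxicity, read by cell counting, with a stated time of 2 days; a lower number here means a stronger inhibitor, a higher number a weaker inhibitor. Compound 1 gives 140000 nM. Compound 2 `CC(C)(C)c1ccc(CN2C(=O)S/C(=C\c3cccc(N)c3)C2=O)cc1`, carrying tert-butyl in place of fluoro on an aromatic carbon, gives 188000 nM. Compound 3 `Nc1cccc(/C=C2\SC(=O)N(Cc3ccccc3)C2=O)c1`, carrying hydrogen in that place, returns > 250000 nM, which is a limit of the assay (the limit of > 250000 nM in this assay, at which 1 of the 3 values shown sits). Compound 1 thus holds the lowest of the two numbers, with compound 2 nearest. The step of a 1.3-fold higher number from compound 1 to compound 2 (0.13 log units; within the scatter) and the step of an at least 1.3-fold higher number from compound 2 to compound 3 (0.12 log units; that floor lies within the scatter) both sit within the scatter, and the step of an at least 1.7-fold higher number from compound 1 to compound 3 (0.25 log units; that floor lies within the scatter) has a floor that also lies within the scatter. Every measured step concerns the substituent on the aromatic carbon of the benzyl group; none touches the amino group.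

Compound 4 `C=C(Br)C(=O)Nc1cccc(/C=C2\SC(=O)N(Cc3ccc(F)cc3)C2=O)c1` differs from compound 1 by (1-bromoethenyl)carbonyl in place of hydrogen on a nitrogen on an aromatic ring, that is, amino to ((1-bromoethenyl)carbonyl)amino. Among the measured compounds shown here, no measured step bears on this change, so the series gives no direction or size for it. The expectation for compound 4 rests only on compound 1 at 140000 nM and is kept wide. Compound 4 is estimated at 70000 nM in this assay, between 10000 nM and 250000 nM. The expected step is a 2.0-fold lower number from compound 1 to compound 4 (0.30 log units; within the scatter), at the edge of the scatter.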

Compound 4, half-maximal inhibitory concentration: 920 nM
Compound 4: the middle estimate sits 76-fold (1.88 log units) above what was measured, and the stated range ends above it.
By their numbers in this assay, from the lowest: compound 4; then compounds 1 and 2 (each within the scatter of the next). At a limit, above all of these: compound 3.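

In this assay, the nitrogen on the aromatic ring proves far more responsive than the aromatic carbon of the benzyl group: amino to ((1-bromoethenyl)carbonyl)amino gives a 150-fold lower number from compound 1 to compound 4 (2.18 log units; beyond the scatter), whereas tert-butyl in place of fluoro gives only a 1.3-fold higher number from compound 1 to compound 2 (0.13 log units; within the scatter). Among the compounds shown here, this is the only change printed as beyond the scatter, so the first clear separation between compounds comes from the amino group and not from the benzyl substituent. Nothing measured here speaks to the cause of this step.

The compounds shown leave open which part of the entering group carries the step: a plain acetyl group on the same nitrogen, or an acryloyl group without the bromine, could hold the number near that of compound 4 or return it towards that of compound 1. Also open, from the compounds shown here alone, is whether the step persists with tert-butyl or hydrogen in place of fluoro on the benzyl group, since the (1-bromoethenyl)carbonyl group appears here only together with fluoro.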